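A few compounds are considered here, and "the series" means these few. Any claim that something is new, unique, unknown or untested is made for them only; others in the source may bear on it.

Compound 1 `Cc1nnc(SCC(=O)c2ccc(Cl)cc2)n1N1C(=O)c2ccccc2C1=O` — in a functional assay on MKN-45 cells (Homo sapiens) for cytotoxicity, read by MTT assay, with a stated time of 48 h (a higher number here means a weaker inhibitor, a lower number a stronger inhibitor), compound 1 sits at the limit > 200000 nM.
Compound 2 `Cc1nnc(SCC(=O)c2ccccc2)n1N1C(=O)c2ccccc2C1=O` — in this assay compound 2 sits at the limit > 200000 nM.
Compound 3 `CCc1nnc(SCC(=O)c2ccccc2)n1N1C(=O)c2ccccc2C1=O` — in this assay compound 3 sits at the limit > 200000 nM.

None of the three measured compounds gives a number in this assay; each is reported only as a limit, which is the point (the limit of > 200000 nM in this assay, at which 3 of the 3 values shown sit). From compound 2 to compound 1 the change is chloro in place of hydrogen on an aromatic carbon, and the step it made is a step that the two limits leave unreadable from compound 2 to compound 1. From compound 2 to compound 3 the cores differ by methyl in place of hydrogen on a saturated chain carbon bound to an aromatic carbon, with a step that the two limits leave unreadable from compound 2 to compound 3.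

Compound 4 `CCc1nnc(SCC(=O)c2ccc(Cl)cc2)n1N1C(=O)c2ccccc2C1=O` has not been measured in this assay. It differs from compound 3 by chloro in place of hydrogen on an aromatic carbon, the same change as that from compound 2 to compound 1, made on the core of compound 3 rather than on the core of compound 2. Since compound 3 is reported only as the limit > 200000 nM, and the step from compound 2 to compound 1 stayed within the limit, the step from compound 3 to compound 4 is expected to be a step that the limit leaves unreadable from compound 3 to compound 4. For compound 4 the expected value in this assay is therefore 300000 nM, with a range estimated from 80000 nM to 1000000 nM, most probably again reported only as a limit.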

Compound 4, half-maximal inhibitory concentration: > 200000 nM
Compound 4: only a limit was reported (the forecaster's own chance of this, stated with the estimate: 85%); the middle value is on the limit's open side.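

Compound 4 gives the limit > 200000 nM in this assay and no number. Going by these compounds alone, no step among compound 1, compound 2, compound 3 and compound 4 can therefore be read, as all four share one limit: the limit of > 200000 nM in this assay, at which 4 of the 4 values shown sit. The compounds shown leave open whether either change, chloro or methyl, alters cytotoxicity at all, and at what concentration any of these compounds would reach half-maximal inhibition.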